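Moving one fluorine: from compound 3 to compound 4

A few compounds are considered here, and "the series" means these few. Any claim that something is new, unique, unknown or untested is made for them only; others in the source may bear on it.

Compound 3, `Fc1ccc(/C=N/NC(=S)Nc2cccc3ccccc23)c(F)c1`, carries a 2,4-difluorophenyl on the carbon double-bonded to nitrogen of the shared core. In an ADME assay on NIH3T3 cells (Mus musculus) for cytotoxicity, read by XTT assay, with a stated time of 24 h (a lower number here means a stronger inhibitor, a higher number a weaker inhibitor), compound 3 reaches only a limit of the assay, > 500 ug/mL. Its two companions stand in the same place. Compound 1, `Fc1cccc(/C=N/NC(=S)Nc2cccc3ccccc23)c1F`, gives in this assay a limit, > 500 ug/mL. Compound 2, `Fc1cc(F)cc(/C=N/NC(=S)Nc2cccc3ccccc23)c1`, gives in this assay a limit as well, > 500 ug/mL. Accordingly, the steps a step that the two limits leave unreadable from compound 1 to compound 2, a step that the two limits leave unreadable from compound 1 to compound 3 and a step that the two limits leave unreadable from compound 2 to compound 3 cannot be sized, because of the limit of > 500 ug/mL in this assay, at which 3 of the 3 values shown sit.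

Compound 4, `Fc1ccc(F)c(/C=N/NC(=S)Nc2cccc3ccccc23)c1`, differs from compound 3 by 2,5-difluorophenyl in place of 2,4-difluorophenyl on a carbon with a double bond to nitrogen. Going by the values given here, no measured step among the three fluorophenyl variants shows any readable movement, so there is nothing that points to compound 4 leaving the limit. Compound 4 is therefore expected to sit at about 800 ug/mL in this assay, between 300 ug/mL and 3000 ug/mL. The step that the limit leaves unreadable from compound 3 to compound 4 is expected to be nothing beyond the scatter, and most likely to remain unreadable.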

Compound 4, half-maximal inhibitory concentration: > 500 ug/mL
Compound 4: only a limit was reported; the forecaster's own chance of this, stated with the estimate: 85%; the middle value does not contradict the limit.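

Compound 4 gives only a limit in this assay, > 500 ug/mL. None of its steps to compound 1, compound 2 and compound 3 can be read: the limit of > 500 ug/mL in this assay, at which 4 of the 4 values shown sit.

The compounds shown leave open whether these four difluorophenyl variants differ at all in this assay.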